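The source may report more compounds than this note shows. Statements on the series, on what has been measured and on what is new or still open speak of the compounds shown alone.

In a functional assay on MT4 cells (Homo sapiens) for cytotoxicity (a lower number here means a stronger inhibitor, a higher number a weaker inhibitor), compound 1 (`N#Cc1c(N)cccc1Sc1ccccc1Br`) gives 41000 nM. Going by these compounds, compound 2 (`Cc1cccc([S+]([O-])c2cccc(N)c2C#N)c1`) gives > 200000 nM, which is a limit of the assay and not a number, so its true position is unknown. Compound 3 (`N#Cc1c(N)cccc1[S+]([O-])c1cccc(C(F)(F)F)c1`) is not yet measured. It carries trifluoromethyl in place of methyl on an aromatic carbon, meta to a large group: trifluoromethyl in place of methyl on an aromatic carbon. Among the measured compounds shown here, no measured pair shows what this change does, so only a small shift toward a lower number is expected, an estimated at least 2.0-fold lower number from compound 2 to compound 3 (0.30 log units; that floor lies within the scatter). The estimated value for compound 3 is 100000 nM, with an expected range from 30000 nM to 200000 nM.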

Compound 3, half-maximal inhibitory concentration: 125000 nM
Compound 3: middle estimate off by 1.3-fold (0.10 log units), on the low side, within the range that was stated.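

In this assay compound 3 gives 125000 nM, so trifluoromethyl at this position yields a measurable number where methyl gave none. The change from methyl to trifluoromethyl gives an at least 1.6-fold lower number from compound 2 to compound 3 (0.20 log units; that floor lies within the scatter). That step is only a floor, because compound 2 stands at a limit of the assay: the limit of > 200000 nM in this assay, at which 1 of the 3 values shown sits.

Going by these compounds, whether other groups at this position, such as an amine or a carboxylic acid, would shift the number remains open. So does the true size of this change in a pair with exact numbers at both ends.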